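The compounds below may be only part of what the source reports. "The series", "measured", "known", "first", "only" and "open" are said of these compounds alone.

In a functional assay on A549 cells (Homo sapiens) for antiproliferative activity, read by MTT assay, with a stated time of 72 h (on this read-out higher numbers stand for weaker inhibition and lower numbers for stronger inhibition), compound 1 `CCC/C=C/C(=O)Nc1cccc(Oc2nc(Nc3ccn(C)n3)nc3c2CSCC3)c1` gives 8190 nM and compound 2 `CC/C=C/C(=O)Nc1cccc(Oc2nc(Nc3ccc(OC)cc3)nc3c2CSCC3)c1` gives 20100 nM, so compound 2 holds the higher, weaker number of the two. Compound 3 `CCC/C=C/C(=O)Nc1cccc(Oc2nc(Nc3ccc(OC)cc3)nc3c2CSCC3)c1` alters compound 2 in one place: methyl in place of hydrogen on a saturated chain carbon, two bonds along the chain from a double-bonded chain carbon. This puts methyl in place of hydrogen on a saturated chain carbon, turning but-1-en-1-yl into pent-1-en-1-yl. Among the compounds with values here, no measured pair shows this change alone, so no step beyond the scatter is expected. The estimated step is a 1.3-fold lower number from compound 2 to compound 3 (0.13 log units; within the scatter), a slight drop at most. For compound 3 the expected value is 15000 nM, with an estimated range of 6000 nM to 38000 nM.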

Compound 3, half-maximal inhibitory concentration: 11900 nM
Estimate against measurement, compound 3: 1.3-fold (0.10 log units) above, within the range that was stated.
By their numbers in this assay, from the lowest: compounds 1, 3 and 2 (each within the scatter of the next, the first and the last beyond it).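

In this assay, going from but-1-en-1-yl to pent-1-en-1-yl gives a 1.7-fold lower number from compound 2 to compound 3 (0.23 log units; within the scatter) and so adds one methyl on this saturated chain carbon without a step beyond the scatter. With the pent-1-en-1-yl chain kept, placing 4-methoxyphenyl in place of 1-methyl-1H-pyrazol-3-yl on the nitrogen gives a 1.5-fold higher number from compound 1 to compound 3 (0.16 log units; within the scatter) and also stays within the scatter. Nothing available offers a reason for either step. Open, on these data alone, is whether a longer chain, such as hex-1-en-1-yl, or an amine on this chain would give a step beyond the scatter.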